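Swapping isopropyl for methyl in a nucleoside prodrug

This account rests on a few compounds, and the source may have more. Where it says the series, first, only, none or still open, it means among the compounds named here.

Measured compounds:
compound 1, `CCCCCc1ccc(-c2cc3cn([C@H]4C[C@H](O)[C@@H](COC(=O)[C@@H](NC(=O)[C@@H]5CCCN5C(=O)[C@@H](N)C(C)C)C(C)C)O4)c(=O)nc3o2)cc1`: > 2000 nM
compound 2, `CCCCCc1ccc(-c2cc3cn([C@H]4C[C@H](OC(=O)[C@@H](NC(=O)[C@@H]5CCCN5C(=O)[C@@H](N)C(C)C)C(C)C)[C@@H](CO)O4)c(=O)nc3o2)cc1`: 60000 nM

In an ADME assay on HEL cells (Homo sapiens) for cytotoxicity (on this read-out lower numbers stand for higher toxicity in this test and higher numbers for lower toxicity in this test), compound 1 gives > 2000 nM, which is a limit of the measurement and not a number (the limit of > 2000 nM in this assay, at which 1 of the 2 values shown sits). In this assay compound 2 gives 60000 nM. Compound 3, `CCCCCc1ccc(-c2cc3cn([C@H]4C[C@H](O)[C@@H](COC(=O)[C@H](C)NC(=O)[C@@H]5CCCN5C(=O)[C@@H](N)C(C)C)O4)c(=O)nc3o2)cc1`, differs from compound 1 by methyl in place of isopropyl on a saturated chain carbon bound to an amide-type nitrogen and a carbonyl carbon. Since the step from compound 1 to compound 3 is unmeasured, its size is expected to stay within the scatter, as a step that the limit leaves unreadable from compound 1 to compound 3. For compound 3 the expected value is 4000 nM, within a range from 1500 nM to 40000 nM, and a limit rather than a number may well be reported.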

Compound 3, minimum cytotoxic concentration in the HEL assay: > 500 nM
Compound 3 was reported as a limit; the forecaster's own chance of this, stated with the estimate: 60%; the middle value is on the limit's open side.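

Going by these compounds alone, compound 1 and compound 3 are both reported as limits in the HEL assay, so no step between them can be read. Going by these compounds, whether methyl in place of isopropyl shifts the value in the HEL assay stays open. In a physicochemical assay, read by HPLC, in phosphate buffer, with a stated time of 24 h, at pH 7.4 (on this read-out lower numbers stand for a less stable compound and higher numbers for a more stable compound), compound 1 gives > 95%, which is a limit of the measurement. In the physicochemical assay compound 3 gives 74%, which makes a number at least 21 percentage points lower from compound 1 to compound 3 (beyond the scatter).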